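Swapping bromo for 4-methylphenyl in a reporter assay

The source may hold more compounds than are shown below. What is called first, only, known or untested is meant among the compounds shown, and "the series" means these compounds.

Compound 1 (`O=C(COc1ccccc1)Nc1cccc(C(=O)O)c1`) reads > 30000 nM in a functional assay on AGS cells (Homo sapiens) for inhibition, read by reporter gene assay (on this read-out higher numbers stand for weaker inhibition and lower numbers for stronger inhibition), as a limit of the assay. Among the measured compounds shown here, compound 2 (`O=C(COc1ccc(Br)cc1)Nc1cccc(C(=O)O)c1`) gives 1600 nM in this assay as the only actual number so far. For the measured compounds named here, the one measured step is an at least 18-fold lower number from compound 1 to compound 2 (1.27 log units; beyond the scatter) and it falls on the aromatic carbon that changes next. Compound 3 (`Cc1ccc(-c2ccc(OCC(=O)Nc3cccc(C(=O)O)c3)cc2)cc1`) differs there by 4-methylphenyl in place of bromo on an aromatic carbon in a single replacement. The large step to compound 2 shows the read-out responds at this carbon, though it sets no size for the new group. A modest further move is expected, a 2.3-fold lower number from compound 2 to compound 3 (0.36 log units; beyond the scatter) as estimated, toward stronger inhibition. Compound 3 is estimated at 700 nM with a range of 150 nM to 3000 nM in this assay for now.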

Compound 3, half-maximal inhibitory concentration: > 30000 nM
Compound 3: only a limit was reported; the forecaster's own chance of this, stated with the estimate: 10%; middle value at least 42-fold (1.63 log units) away from the limit.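

Putting 4-methylphenyl in place of bromo on this aromatic carbon gives an at least 18-fold higher number from compound 2 to compound 3 (1.27 log units; beyond the scatter) in this assay, so the stronger inhibition seen with bromo does not persist with this group. The read-out at this carbon therefore depends on which group sits there, not merely on hydrogen being replaced. Compound 1 and compound 3 both end at a limit, so the step between them cannot be read: the limit of > 30000 nM in this assay, at which 2 of the 3 values shown sit.

Open, going by these compounds, is whether chloro, methyl or an unsubstituted phenyl at this carbon would keep the inhibition seen with bromo.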